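The compounds below may be only part of what the source reports. "The series", "measured", "known", "first", "only" and "open" are said of these compounds alone.

Working notes on the series. Compound 1 `CN1CCCN(CCCS(=O)(=O)c2ccc3nc(NC(=O)NC(=O)c4ccccc4Cl)sc3c2)CC1` is measured in an assay on HEK293 cells for displacement of a labelled ligand from growth hormone secretagogue receptor type 1 (Homo sapiens), with a stated time of 60 min (on this read-out lower numbers stand for stronger inhibition and higher numbers for weaker inhibition), and gives 4.2 nM. Among the compounds with values here, compound 2 `CN1CCC(S(=O)(=O)c2ccc3nc(NC(=O)NC(=O)c4cc5c(cc4Cl)CCN5C)sc3c2)CC1` gives 7.2 nM in this assay; the two values lie within the usual scatter of each other, and the two structures differ in more than one place, so no single step between them is read. Compound 3 `CC(C)NCCS(=O)(=O)c1ccc2nc(NC(=O)NC(=O)c3ccccc3Cl)sc2c1` is not yet measured in this assay. Relative to compound 1 the change is isopropylamino in place of (4-methyl-1,4-diazepan-1-yl)methyl on a saturated chain carbon, two bonds along the chain from a sulfonyl sulfur: the sulfonyl-bearing chain keeps one basic nitrogen but loses the seven-membered ring and gains a hydrogen-bond donor. Within the data shown here, with no step of this kind measured, a small move toward weaker inhibition is expected rather than a change beyond the scatter; the step from compound 1 to compound 3 is estimated as a 1.9-fold higher number from compound 1 to compound 3 (0.28 log units; within the scatter). For compound 3 the expected value in this assay is 8 nM, with a range from 2.5 nM to 25 nM.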

Compound 3, half-maximal inhibitory concentration: 27 nM
Compound 3: the middle estimate sits 3.4-fold (0.53 log units) below what was measured; the measured number lies above the stated range.
By their numbers in this assay, from the lowest: compounds 1 and 2 (each within the scatter of the next); then compound 3.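

In this assay, within the data shown here, this place on the sulfonyl-bearing chain proves sensitive to the group it carries: isopropylamino in place of (4-methyl-1,4-diazepan-1-yl)methyl gives a 6.4-fold higher number from compound 1 to compound 3 (0.81 log units; beyond the scatter), the first single-place step that can be read. The same difference also reads as 3-(4-methyl-1,4-diazepan-1-yl)propyl to 2-(isopropylamino)ethyl, so the step combines the loss of the seven-membered ring, a shorter chain and the gain of a hydrogen-bond donor. No measurement shown on these compounds gives a reason for the step.

From the compounds shown here alone, how the step divides among those parts remains open, since all of them change together between these two compounds. Isopropylamino on a longer chain, or a 4-methylpiperazin-1-yl group on the chain of compound 3, would each separate one part from the others.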